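Amide side-chain variation in the shared core series

The source may hold more compounds than are shown below. What is called first, only, known or untested is meant among the compounds shown, and "the series" means these compounds.

In an assay on LtK cells with ATP-sensitive inward rectifier potassium channel 11 (Homo sapiens) as the target (a higher number here means that more compound is needed for the effect, a lower number that less compound is needed), compound 3 `O=C(CC1CCCC1)Nc1c(C(O)(C(F)(F)F)C(F)(F)F)ccc2ccccc12` gives 81 nM, the second highest of the three numbers measured. Compound 1 `CCC(=O)Nc1c(C(O)(C(F)(F)F)C(F)(F)F)ccc2ccccc12` gives 15 nM and compound 2 `O=C(Nc1c(C(O)(C(F)(F)F)C(F)(F)F)ccc2ccccc12)C1CC1` gives 751 nM; the steps read a 5.4-fold higher number from compound 1 to compound 3 (0.73 log units; beyond the scatter) and a 9.3-fold lower number from compound 2 to compound 3 (0.97 log units; beyond the scatter). Compound 4 `O=C(CCc1ccccc1)Nc1c(C(O)(C(F)(F)F)C(F)(F)F)ccc2ccccc12` differs from compound 3 by benzyl in place of cyclopentyl on a saturated chain carbon bound to a carbonyl carbon. Going by the values given here, the only measured step at the same saturated chain carbon, a 5.4-fold higher number from compound 1 to compound 3 (0.73 log units; beyond the scatter), is modest, and no measured step exchanges one ring for another at that place, so the direction is open. Trading the five-membered non-aromatic ring for benzyl is expected to move this assay little, and compound 4 is estimated at 100 nM with a range of 30 nM to 330 nM, an expected step of a 1.2-fold higher number from compound 3 to compound 4 (0.09 log units; within the scatter).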

Compound 4, half-maximal effective concentration: 1750 nM
Estimate against measurement, compound 4: 18-fold (1.24 log units) below; the measured number lies above the stated range.
By their numbers in this assay, from the lowest: compound 1; then compound 3; then compound 2; then compound 4.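

In this assay, going by these compounds alone, the ring on the saturated chain carbon turns out not to be interchangeable: the only ring-for-ring exchange at this place gives a large step (a 22-fold higher number from compound 3 to compound 4 (1.33 log units; beyond the scatter)). Phenethyl also reads above the cyclopropyl amide (a 2.3-fold higher number from compound 2 to compound 4 (0.37 log units; beyond the scatter)), and phenyl in place of hydrogen on the propanamide chain gives the largest step shown (a 120-fold higher number from compound 1 to compound 4 (2.07 log units; beyond the scatter)). No measurement shown here explains the effect of the aromatic ring.

Open, on these data alone, is whether a cyclohexyl group at this place stays near compound 3, which would separate ring size from aromaticity. Also open, as far as these compounds go, is how an amine at the end of a longer chain would read.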